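The compounds below may be only part of what the source reports. "The series", "measured", "known", "first", "only" and "open" are said of these compounds alone.

Measured in an ADME assay on BHK-21 cells (Mesocricetus auratus) for cytotoxicity, read by MTT assay, with a stated time of 72 h; a lower number here means that less compound is tolerated, a higher number that more compound is tolerated:
compound 1 `NS(=O)(=O)c1ccc(N2N=C(c3ccccc3)CC2c2ccccc2Cl)cc1` gives 13000 nM
compound 2 `NS(=O)(=O)c1ccc(N2N=C(c3ccc(OCc4ccccc4)cc3)CC2c2ccccc2)cc1` gives 80000 nM
compound 3 `NS(=O)(=O)c1ccc(N2N=C(c3ccc(Oc4ccccc4)cc3)CC2c2ccccc2)cc1` gives 11000 nM

Compound 2, at 80000 nM, has the highest number of the three. Compound 4 `NS(=O)(=O)c1ccc(N2N=C(c3ccc(OCc4ccccc4)cc3)CC2c2ccccc2Cl)cc1` differs from it by one change, chloro in place of hydrogen on an aromatic carbon, ortho to a large group: chloro in place of hydrogen on an aromatic carbon. Within the data shown here, no measured step makes this change. Among the measured compounds shown here, the only step, a 7.3-fold lower number from compound 2 to compound 3 (0.86 log units; beyond the scatter), lies elsewhere in the molecule and shows just that a single change can move this number. Compound 1 carries the same 2-chlorophenyl and gives 13000 nM, but it also differs from compound 2 elsewhere. A modest drop in this assay is therefore expected, though loosely. The expected change is a 2.0-fold lower number from compound 2 to compound 4 (0.30 log units; within the scatter) in this estimate. The estimated value for compound 4 is 40000 nM, with an expected range of 12000 nM to 110000 nM.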

Compound 4, half-maximal cytotoxic concentration: 12000 nM
For compound 4 the middle estimate is 3.3-fold (0.52 log units) above the measured one; the measured number falls inside the stated range.
By their numbers in this assay, from the lowest: compounds 3, 4 and 1 (each within the scatter of the next); then compound 2.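

In this assay, chloro in place of hydrogen, ortho to a large group, has a clear effect of its own (a 6.7-fold lower number from compound 2 to compound 4 (0.82 log units; beyond the scatter)), and this step lies beyond the scatter. With the 2-chlorophenyl present, benzyloxy in place of hydrogen leaves the number within the scatter (a 1.1-fold lower number from compound 1 to compound 4 (0.03 log units; within the scatter)). Nothing measured here explains this result.

Going by these compounds, whether fluoro or methoxy at this position would act as chloro does remains open. So does whether chloro would have a similar effect alongside the phenoxy group of compound 3.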